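A few compounds are considered here, and "the series" means these few. Any claim that something is new, unique, unknown or untested is made for them only; others in the source may bear on it.

Compound 3 `COC(=O)c1cc(N)c(Nc2ccc(C#N)cc2)cc1Oc1c(OC)cc(CCC#N)cc1OC` stands at the high end of the three numbers in an ADME assay on TZM cells (Homo sapiens) for cytotoxicity, with a stated time of 1 days (a lower number here means that less compound is tolerated, a higher number that more compound is tolerated), with 128000 nM, yet within the scatter of both others: compound 2 `Cc1cc(CCC#N)cc(C)c1Oc1cc(Nc2ccc(C#N)cc2)c(N)cc1C(=O)NC1CC1` gives 121000 nM and compound 1 `CCNC(=O)c1cc(N)c(Nc2ccc(C#N)cc2)cc1Oc1c(C)cc(CCC#N)cc1C` gives 105000 nM. Compound 4 `CNC(=O)c1cc(N)c(Nc2ccc(C#N)cc2)cc1Oc1c(OC)cc(CCC#N)cc1OC` differs from compound 3 by methylamino in place of methoxy on a carbonyl carbon, which read one bond further out is methoxycarbonyl to methylcarbamoyl. Within the data shown here, no measured pair shows this change directly. Among the measured compounds shown here, the only measured step, a 1.2-fold higher number from compound 1 to compound 2 (0.06 log units; within the scatter), concerns the substituent on an amide-type nitrogen and stayed within the scatter. Compounds 1 and 2, carrying an amide-type carbonyl with ethyl or cyclopropyl on the nitrogen, and compound 3, carrying the methoxycarbonyl, all sit within the scatter of one another, though their other aryl ring also differs, so the carbonyl substituent cannot be read apart from that ring. On this basis no step beyond the scatter is expected for compound 4 in this assay. The expected step is a 1.0-fold lower number from compound 3 to compound 4 (0.01 log units; within the scatter). Compound 4 is accordingly estimated at 125000 nM, with a range from 60000 nM to 250000 nM.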

Compound 4, half-maximal cytotoxic concentration: 42600 nM
Beside the measured number, compound 4's estimate is 2.9-fold (0.47 log units) above it; the measured number lies below the stated range.
By their numbers in this assay, from the lowest: compound 4; then compounds 1, 2 and 3 (each within the scatter of the next).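

In this assay, with the rest of the molecule held constant, replacing methoxy with methylamino on a carbonyl carbon gives a 3.0-fold lower number from compound 3 to compound 4 (0.48 log units; beyond the scatter), so the group on this carbonyl can shift the number beyond the scatter. Among these compounds, the earlier step, a 1.2-fold higher number from compound 1 to compound 2 (0.06 log units; within the scatter), changed only the substituent on an amide-type nitrogen and stayed within the scatter; it gave no sign that this position could matter, and the new step is the first single-place change here that moves the number beyond the scatter. The change exchanges an oxygen for a nitrogen and introduces the hydrogen-bond donor of methylamino, but no measurement ties the step to either feature or otherwise accounts for it.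

Still open, going by these compounds, is where dimethylamino or a hydroxyl, the latter giving a free carboxylic acid, would fall on the same carbonyl carbon relative to compound 3 and compound 4. Also open, on these data alone, is whether the exchange of methoxycarbonyl for methylcarbamoyl would give a step of similar size with the other aryl ring carried by compound 1 and compound 2.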